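The source may report more compounds than this note shows. Statements on the series, on what has been measured and on what is new or still open speak of the compounds shown alone.

Compound 1 `NC1=NC2(CCSCC2)N(OCCCOc2cc(Cl)c(Cl)cc2Cl)C(N)=N1` and compound 2 `NC1=NC2(CCOCC2)N(OCCCOc2cc(Cl)c(Cl)cc2Cl)C(N)=N1` carry the same side chain on cores that differ; how the two cores differ is not broken down here. In an assay on isolated protein for inhibition of Dihydrofolate reductase (Homo sapiens), read by spectrophotometry, using NADPH, with stated times of 5 s and 6 min, tested at 5 uM (a higher number here means a stronger effect of the compound at the concentration tested, a lower number a weaker effect), compound 1 gives 84.4%. Compound 2 reaches > 90%, which is a limit of the assay rather than a number (the limit of > 90% in this assay, at which 1 of the 3 values shown sits). Compound 3 `NC1=NC2(CCOCC2)N(OCCCOc2ccccc2Br)C(N)=N1` differs from compound 2 by 2-bromophenyl in place of 2,4,5-trichlorophenyl on an oxygen on a saturated carbon, and in this assay compound 3 gives 83.8%, so that a number at least 6.2 percentage points lower from compound 2 to compound 3 (that floor lies within the scatter). Compound 4 `NC1=NC2(CCSCC2)N(OCCCOc2ccccc2Br)C(N)=N1` has not yet been measured and differs from compound 1 by the same change, (2-bromophenyl in place of 2,4,5-trichlorophenyl on an oxygen on a saturated carbon). The step from compound 1 to compound 4 is expected to be a number 6.4 percentage points lower from compound 1 to compound 4 (within the scatter), because the same change gave a number at least 6.2 percentage points lower from compound 2 to compound 3 (that floor lies within the scatter) and compound 1 starts from a number rather than a limit. Compound 4 is therefore estimated at 78% in this assay.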

Compound 4, a percentage reported as inhibition, at one concentration (the size of the read-out at that concentration, not a potency): 88.7%
Estimate against measurement, compound 4: 10.7 percentage points below; measured number above the stated range.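

In this assay, putting 2-bromophenyl in place of 2,4,5-trichlorophenyl gives a number 4.3 percentage points higher from compound 1 to compound 4 (within the scatter), so on this core the two groups cannot be told apart. Set beside the same change on the other core, the result reads: the same change on two cores in this assay, a number at least 6.2 percentage points lower (that floor lies within the scatter) from compound 2 to compound 3 and a number 4.3 percentage points higher (within the scatter) from compound 1 to compound 4; the limit leaves it open whether they differ. The value of compound 2 is a limit and not a number, so these two steps show neither that the change carries over unaltered from one core to the other nor that the core alters it: the limit of > 90% in this assay, at which 1 of the 4 values shown sits.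

The compounds shown leave open what an amine or a carboxylic acid would do in place of the phenyl ring, and what a longer chain would do in place of the present one. From the compounds shown here alone, each value comes from a single concentration and gives the size of the effect at that concentration, so how the compounds would compare at any other concentration also stays open.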